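The source may report more compounds than this note shows. Statements on the series, on what has been measured and on what is new or still open speak of the compounds shown alone.

Two compounds share a core in which a 4-hydroxyphenyl group sits on a six-membered aromatic ring with one nitrogen. Compound 1, `Oc1ccc(-c2cc(-c3cccc(F)c3)cc(-c3cccc(O)c3)n2)cc1`, carries a fluorophenyl and a 3-hydroxyphenyl on that core; in a functional assay on T47D cells (Homo sapiens) for inhibition (a lower number here means a stronger inhibitor, a higher number a weaker inhibitor), compound 1 gives 3510 nM. Compound 2, `Oc1ccc(-c2cc(-c3cccc(OC(F)(F)F)c3)cc(-c3ccccc3O)n2)cc1`, carries a trifluoromethoxyphenyl and a 2-hydroxyphenyl instead. In this assay compound 2 reaches only a limit, > 50000 nM, so no number is known for it. It stands at the limit of > 50000 nM in this assay, at which 1 of the 2 values shown sits. The next compound, compound 3, `Oc1ccc(-c2cc(-c3cccc(OC(F)(F)F)c3)cc(-c3cccc(O)c3)n2)cc1`, differs from compound 2 by 3-hydroxyphenyl in place of 2-hydroxyphenyl on an aromatic carbon. It thus pairs the trifluoromethoxyphenyl of compound 2 with the 3-hydroxyphenyl of compound 1. Because compound 1 gives 3510 nM with that 3-hydroxyphenyl, compound 3 is expected to move toward stronger inhibition, a step estimated as an at least 6.2-fold lower number from compound 2 to compound 3 (0.79 log units; beyond the scatter). Compound 3 is estimated at 8000 nM, with a range from 2000 nM to 50000 nM.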

Compound 3, half-maximal inhibitory concentration: 5040 nM
Beside the measured number, compound 3's estimate is 1.6-fold (0.20 log units) above it, and the stated range covers the measured number.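

In this assay, the position next to the ring nitrogen proves sensitive to where the hydroxyl sits on its phenyl group: 3-hydroxyphenyl in place of 2-hydroxyphenyl gives an at least 9.9-fold lower number from compound 2 to compound 3 (0.99 log units; beyond the scatter) and shows that this change alone separates the two compounds. The size of that step is only a lower bound, as compound 2 has a limit and not a number: the limit of > 50000 nM in this assay, at which 1 of the 3 values shown sits. Trifluoromethoxy in place of fluoro gives a 1.4-fold higher number from compound 1 to compound 3 (0.16 log units; within the scatter) and so does not separate the two compounds that carry 3-hydroxyphenyl.

The compounds shown leave open how 2-hydroxyphenyl would read alongside fluoro instead of trifluoromethoxy. They also leave open what an amine or a carboxylic acid on the phenyl group at this position would do.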